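A few compounds are considered here, and "the series" means these few. Any claim that something is new, unique, unknown or untested is made for them only; others in the source may bear on it.

Compound 1 `Cc1ccc(Cc2cn3cc(Cl)ccc3nc2=O)cc1`: > 1000000 nM (a limit)
Compound 2 `O=c1nc2ccc(Cl)cn2cc1Cc1ccc(F)cc1`: 98300 nM

In a functional assay on A549 cells (Homo sapiens) for cytotoxicity, read by MTT assay, with a stated time of 24 h (a higher number here means a weaker inhibitor, a lower number a stronger inhibitor), compound 1 reaches only a limit, > 1000000 nM. For the measured compounds named here, compound 2 gives 98300 nM, the only actual number available so far. Its standing therefore rests on a single comparison with compound 1. The next compound, compound 3 `O=c1nc2ccc(Cl)cn2cc1Cc1ccc([N+](=O)[O-])cc1`, keeps the core of compound 2 and carries nitro in place of fluoro on an aromatic carbon, para to a large group: nitro in place of fluoro on an aromatic carbon. Going by the values given here, one measured step bears on this carbon, an at least 10-fold lower number from compound 1 to compound 2 (1.00 log units; beyond the scatter), which lies beyond the scatter and shows that this assay can respond to a change there. That step replaced methyl with fluoro, not with nitro, so it gives size more than direction. A modest move to a lower number is expected, as a 2.0-fold lower number from compound 2 to compound 3 (0.29 log units; within the scatter). For compound 3 the estimated value is 50000 nM, with an expected range from 12000 nM to 200000 nM.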

Compound 3, half-maximal inhibitory concentration: > 1000000 nM
Compound 3 ended at the assay's limit; the forecaster's own chance of this, stated with the estimate: 10%; middle value at least 20-fold (1.30 log units) from the limit.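

In this assay, nitro in place of fluoro on this aromatic carbon gives an at least 10-fold higher number from compound 2 to compound 3 (1.00 log units; beyond the scatter), the opposite direction to an at least 10-fold lower number from compound 1 to compound 2 (1.00 log units; beyond the scatter). Of the three groups shown at this carbon, only fluoro gives an actual number, so the fall seen on leaving methyl does not extend to every group placed there. The step between compound 1 and compound 3 cannot be read, and methyl and nitro therefore cannot be ordered: the limit of > 1000000 nM in this assay, at which 2 of the 3 values shown sit.

Going by these compounds, whether fluoro is unusual at this carbon remains open, as an amine, a methoxy group or a carboxylic acid there could either give a number or stay at the limit. Also open, on these data alone, is whether the response at this carbon would hold with another group in place of the chloro on the shared core.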